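The compounds below may be only part of what the source reports. "The series", "measured", "known", "first", "only" and "open" are said of these compounds alone.

Compound 1 `CC[C@H]1c2c(cc(F)c(F)c2O)[C@H](Nc2cccc3[nH]c(=O)ccc23)[C@@](O)(C(F)(F)F)C1OC`: 78%
Compound 2 `CCSC[C@@](O)([C@@H](Nc1cccc2nc(C)ccc12)c1ccc(Cl)c(F)c1OC)C(F)(F)F`: 82%
Compound 3 `COc1ccc([C@H](Nc2cccc3nc(C)ccc23)[C@](O)(CSC)C(F)(F)F)c(Cl)c1F`: 98%

In a functional assay on THP-1 cells (Homo sapiens) (a higher number here means a larger maximal response, a lower number a smaller maximal response), compound 3 gives the highest of these three numbers. The nearest value belongs to compound 2, and the furthest to compound 1, and both gaps lie beyond the usual scatter of such measurements. Among the measured compounds shown here, compound 4 `COC[C@@](O)([C@@H](Nc1cccc2nc(C)ccc12)c1ccc(OC)c(F)c1Cl)C(F)(F)F` is the unmeasured partner of compound 3; the single change between them is methoxy in place of methylsulfanyl on a saturated chain carbon, two bonds along the chain from an oxygen on a saturated carbon. For the measured compounds named here, no pair of measured compounds shows this same change, so there is no measured step to lean on. Because compound 3 already gives 98%, the step is expected to be small and slightly downward, at most at the edge of the scatter, as a number 6 percentage points lower from compound 3 to compound 4 (within the scatter). For compound 4 the estimated largest response is 92%, expected to lie between 80% and 102%.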

Compound 4, largest response reached (Emax), in percent of the reference or control that the assay uses in the THP-1 assay: 97%
Beside the measured number, compound 4's estimate is 5 percentage points below it; low and high end bracket the measured number.
By their numbers in the THP-1 assay, from the lowest: compounds 1 and 2 (each within the scatter of the next); then compounds 4 and 3 (each within the scatter of the next).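

In the THP-1 assay the change from methylsulfanyl to methoxy gives a number 1 percentage points lower from compound 3 to compound 4 (within the scatter), so at this position the maximal response does not depend on the sulfur. In a physicochemical assay for lipophilicity (on this read-out higher numbers stand for higher lipophilicity and lower numbers for lower lipophilicity), compound 3 gives 4.5 and compound 4 gives 3.8, a gap beyond the usual scatter. The swap therefore moves the partition coefficient while the maximal response holds.

The compounds shown leave open how far this tolerance extends. A longer chain such as ethoxy, or an amine such as dimethylamino, in the same place could still hold or lose the response.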